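A few compounds are considered here, and "the series" means these few. Any claim that something is new, unique, unknown or untested is made for them only; others in the source may bear on it.

Measured compounds:
Compound 1, `CCc1cc(S(=O)(=O)N2C[C@H](c3ccccc3)NC2=O)ccc1NC(=O)OC`, gives 200 nM in a functional assay on HCT-116 cells (Homo sapiens) for cytotoxicity, read by MTT assay; on this read-out higher numbers stand for weaker inhibition and lower numbers for stronger inhibition.
Compound 2, `CCc1cc(S(=O)(=O)N2C[C@H](c3ccccc3)NC2=O)ccc1NC(=O)OC(C)C`, gives 60 nM in this assay.
Compound 3, `CCc1cc(S(=O)(=O)N2C[C@H](c3ccccc3)NC2=O)ccc1NC(=O)c1ccc([N+](=O)[O-])cc1`, gives 500 nM in this assay.

Compound 2 stands at the low end of these three numbers. The steps of a 3.3-fold lower number from compound 1 to compound 2 (0.52 log units; beyond the scatter) and an 8.3-fold higher number from compound 2 to compound 3 (0.92 log units; beyond the scatter) are both beyond the scatter, and a 2.5-fold higher number from compound 1 to compound 3 (0.40 log units; beyond the scatter) completes the ordering with compound 3 at the high end.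

Compound 4, `CCc1cc(S(=O)(=O)N2C[C@H](c3ccccc3)NC2=O)ccc1NC(=O)NC1CCCCC1`, differs from compound 2 in one place: cyclohexylamino in place of isopropoxy on a carbonyl carbon. Among the measured compounds shown here, two measured steps bear on this. The step of a 3.3-fold lower number from compound 1 to compound 2 (0.52 log units; beyond the scatter) shows that a larger alkyl on the oxygen of the (isopropoxycarbonyl)amino group lowered the number, while the step of an 8.3-fold higher number from compound 2 to compound 3 (0.92 log units; beyond the scatter) shows that replacing the isopropoxy on the carbonyl carbon by 4-nitrophenyl raised it. Neither step covers a swap to an amino-type group bearing a hydrogen-bond donor, so the direction is uncertain. Compound 4 is therefore expected to give a modest rise in this assay, a 1.8-fold higher number from compound 2 to compound 4 (0.26 log units; within the scatter), with the estimate for compound 4 at 110 nM, ranging from 30 nM to 400 nM.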

Compound 4, half-maximal inhibitory concentration: 300 nM
Compound 4: middle estimate off by 2.7-fold (0.44 log units), on the low side, within the range that was stated.
By their numbers in this assay, from the lowest: compound 2; then compounds 1, 4 and 3 (each within the scatter of the next, the first and the last beyond it).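

In this assay, cyclohexylamino on this carbonyl carbon gave a 5.0-fold higher number from compound 2 to compound 4 (0.70 log units; beyond the scatter), so this group, the only one shown here that brings a hydrogen-bond donor and a non-aromatic ring, does not keep the low number seen with isopropoxy. Against the other two groups it does not stand apart: a 1.7-fold lower number from compound 3 to compound 4 (0.22 log units; within the scatter) and a 1.5-fold higher number from compound 1 to compound 4 (0.18 log units; within the scatter) both lie within the scatter, although methoxy and 4-nitrophenyl are themselves separated beyond it. Nothing available here explains the result for this change.

The compounds shown leave open whether the higher number goes with the nitrogen or with the cyclohexyl ring; isopropylamino and cyclohexyloxy on the same carbonyl carbon would separate the two. Also open, going by these compounds, is whether a tert-butoxy group at this place would go lower than isopropoxy.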